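The compounds below may be only part of what the source reports. "The series", "measured", "known", "first", "only" and "open" are said of these compounds alone.

Three compounds sharing one core have been examined in a functional assay on PC-3 cells (Homo sapiens) for inhibition, read by sulforhodamine B assay, with a stated time of 48 h, tested at 50 uM (on this read-out lower numbers stand for less inhibition of growth and higher numbers for more inhibition of growth at the one concentration tested), so far. Compound 1 (`COc1ccccc1/C=C/C(=O)/C=C/c1ccc(OCc2cn(CCCOc3cc(=O)oc4ccccc34)nn2)c(OC)c1`) is recorded as "not active" (no number reported) without any number. Compound 2 (`COc1ccc(/C=C/C(=O)/C=C/c2ccc(OCc3cn(CCCOc4cc(=O)oc5ccccc45)nn3)c(OC)c2)cc1OC`) gives 9% and supplies the only figure in the set. Compound 3 (`COc1ccc(/C=C/C(=O)/C=C/c2ccc(OCc3cn(CCCOc4cc(=O)oc5ccccc45)nn3)c(OC)c2)cc1`) is recorded as "not active" (no number reported) and so has no single number of its own. It shares that verdict with compound 1, and its standing can be told only in those words, not as a point on the scale.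

Compound 4 (`COc1cc(/C=C/C(=O)/C=C/c2cccs2)ccc1OCc1cn(CCCOc2cc(=O)oc3ccccc23)nn1`) has not yet been measured. It differs from compound 3 by thiophen-2-yl in place of 4-methoxyphenyl on a double-bonded chain carbon bound to a double-bonded chain carbon. Going by the values given here, no measured pair in the set shows what such an exchange does in this assay and the size of the step cannot be read from the data. A step beyond the usual scatter, in either direction, is therefore not expected. This expectation rests on compound 3 at "not active" (no number reported) and on compound 2 at 9% as the only kinds of result seen so far. For compound 4 an inhibition of 8% is expected, with an estimated range from 0% to 22% as its ends.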

Compound 4, percent growth inhibition at one concentration: "not active" (no number reported)
Compound 4 has no reported number here, so the estimate cannot be set against anything.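

Going by these compounds alone, compound 3 and compound 4 are both recorded in this assay as verdicts without a number, so no step between them can be read. Nothing shown bears on a reason for this result. The compounds shown leave open what replacing 4-methoxyphenyl with thiophen-2-yl does to growth inhibition in numerical terms.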